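The source may report more compounds than this note shows. Statements on the series, on what has been measured and on what is new or still open speak of the compounds shown alone.

Measured in a functional assay on WM164 cells (Homo sapiens) for antiproliferative activity, read by sulforhodamine B assay, with a stated time of 48 h; on this read-out lower numbers stand for stronger inhibition and higher numbers for weaker inhibition:
- compound 1 `CCCCCCCCCCCCCCNC(=O)[C@@H]1CSC(c2cc(OC)c(OC)c(OC)c2)N1`: 1600 nM
- compound 2 `CCCCCCCCCCCCNC(=O)[C@@H]1CSC(c2ccc(OC)c(OC)c2)N1`: 1600 nM
- compound 3 `CCCCCCCCCCCCNC(=O)[C@@H]1CSC(c2ccc(NC(C)=O)cc2)N1`: 1200 nM

Compound 3, at 1200 nM, lies within the usual scatter of both other compounds, so the three cannot be ranked. The change to compound 4 `CCCCCCCCCCCCCCCCCNC(=O)[C@@H]1CSC(c2ccc(NC(C)=O)cc2)N1` is pentyl in place of hydrogen on a saturated chain carbon, ten or more bonds along the chain from an amide-type nitrogen, which lengthens the chain. Within the data shown here, the only measured step, a 1.3-fold lower number from compound 2 to compound 3 (0.12 log units; within the scatter), lies within the scatter and leaves the chain unchanged. Among the measured compounds shown here, no measured step changes the chain alone, so the data give neither a size nor a direction for this change. A shift beyond the scatter is therefore not expected, although the uncertainty is wide. The expected size is a 1.1-fold lower number from compound 3 to compound 4 (0.04 log units; within the scatter). For compound 4 the estimated value in this assay is 1100 nM, with an expected range from 450 nM to 2600 nM.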

Compound 4, half-maximal inhibitory concentration: 2400 nM
Compound 4: middle estimate off by 2.2-fold (0.34 log units), on the low side, and the stated range covers the measured number.
By their numbers in this assay, from the lowest: compounds 3, 1, 2 and 4 (each within the scatter of the next).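

In this assay, among these compounds, pentyl in place of hydrogen on a saturated chain carbon gives a 2.0-fold higher number from compound 3 to compound 4 (0.30 log units; within the scatter) and is the first measured step that changes the chain alone. So this longer chain is tolerated here, with no shift beyond the scatter. No available evidence bears on this result.

From the compounds shown here alone, whether a shorter chain, or an amine or a carboxylic acid on the chain, would shift the number beyond the scatter remains open. So does whether the same lengthening would act alike with 3,4-dimethoxyphenyl on the shared core.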